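The compounds below may be only part of what the source reports. "The series", "measured", "known", "first", "only" and "open" are said of these compounds alone.

Of the compounds shown here, three built on one shared core have been measured so far: compound 1 `N#C/C(=C\c1c(-c2ccccc2)[nH]c2ccccc12)C(=O)N1CCCCC1`, compound 2 `CCOC(=O)/C(=C/c1c(-c2ccccc2)[nH]c2ccccc12)C(=O)c1ccc(Cl)cc1` and compound 3 `O=C(C(=Cc1c(-c2ccccc2)[nH]c2ccccc12)C(=O)c1ccccc1)c1ccccc1`. In a functional assay on MT4 cells (Homo sapiens) for antiproliferative activity, read by MTT assay, with a stated time of 96 h (on this read-out lower numbers stand for an effect already at smaller amounts and higher numbers for an effect only at larger amounts of compound), compound 1 gives 9600 nM. In this assay compound 2 gives 9000 nM, and compound 3 gives 8900 nM. Compound 1 carries the largest of the three figures, yet its distance to compound 2 and to compound 3 is within the usual scatter, so the three cannot be told apart on these numbers.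

The next compound is compound 4 `N#C/C(=C\c1c(-c2ccccc2)[nH]c2ccccc12)S(=O)(=O)c1ccccc1`. Compared with compound 1 the change is phenylsulfonyl in place of (piperidin-1-yl)carbonyl on a double-bonded chain carbon bound to a double-bonded chain carbon and a triple-bonded carbon. Among the measured compounds shown here, no pair of measured compounds differs in only one place, so there is no measured step to lean on. What the three figures do show is that rather different groups at the same chain position all land close together, which argues for a small step at most, in no clear direction. For compound 4 the estimate is 9000 nM, with a range from 3000 nM to 27000 nM, and the expected step of a 1.1-fold lower number from compound 1 to compound 4 (0.03 log units; within the scatter) is one that stays inside the scatter.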

Compound 4, half-maximal effective concentration: 400 nM
For compound 4 the middle estimate is 23-fold (1.35 log units) above the measured one; measured number outside the range, below it.
By their numbers in this assay, from the lowest: compound 4; then compounds 3, 2 and 1 (each within the scatter of the next).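

Replacing (piperidin-1-yl)carbonyl with phenylsulfonyl gives a 24-fold lower number from compound 1 to compound 4 (1.38 log units; beyond the scatter) in this assay, so the group at this place on the chain can matter a great deal, which the close figures of the three earlier compounds gave no hint of. The change swaps two things at once, a carbonyl for a sulfonyl and a non-aromatic ring for an aromatic one, and this single step cannot say which of them accounts for the drop. Nothing measured here explains why the number falls so far.

Which part of phenylsulfonyl carries the step therefore stays open. A methylsulfonyl group at this place, or a benzoyl group with the nitrile kept, would help separate the contribution of the sulfonyl from that of the aromatic ring.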